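Positional Isomers of a Chlorobenzyl Thioether in Rat Artery

The source may report more compounds than this note shows. Statements on the series, on what has been measured and on what is new or still open speak of the compounds shown alone.

The study compares four compounds that share a thioether bearing a chlorinated benzyl group, read in a functional assay on the whole organism (artery, strain albino) with Rattus norvegicus as the target, with a stated time of 900 min, at a dose of 10 mg/kg by the oral route; on this read-out lower numbers stand for less inhibition and higher numbers for more inhibition at the one dose given (going by the name of the read-out). Compound 1 `COc1ccc(C2N=C(SCc3ccccc3Cl)NC(C)=C2C(=O)Nc2ccc(F)cc2)cc1OC` and compound 2 `COc1ccc(C2N=C(SCc3cccc(Cl)c3)NC(C)=C2C(=O)Nc2ccc(F)cc2)cc1OC` carry the same core, and compound 3 `CC1=C(C(=O)Nc2ccc([N+](=O)[O-])cc2)C(c2ccc(Br)cc2)N=C(SCc2ccccc2Cl)N1` and compound 4 `CC1=C(C(=O)Nc2ccc([N+](=O)[O-])cc2)C(c2ccc(Br)cc2)N=C(SCc2cccc(Cl)c2)N1` carry a second core; the difference between the two cores is not broken down here.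

In this assay compound 1 gives 21%, and compound 2 gives 13.3%. The change between them is 3-chlorophenyl in place of 2-chlorophenyl on a saturated chain carbon bound to a sulfur, and it made a step of a number 7.7 percentage points lower from compound 1 to compound 2 (within the scatter). In this assay compound 3 gives 4.1%, a value within the scatter of compound 2 and lower than that of compound 1, that gap lying beyond the scatter.

Compound 4 differs from compound 3 by 3-chlorophenyl in place of 2-chlorophenyl on a saturated chain carbon bound to a sulfur, the same change as between compound 1 and compound 2, at the same place. Because the earlier step was a number 7.7 percentage points lower from compound 1 to compound 2 (within the scatter), a step of similar size is expected from compound 3 to compound 4, namely a number 2.1 percentage points lower from compound 3 to compound 4 (within the scatter), with the read-out unable to fall far since compound 3 already sits near the bottom of the scale with 4.1%. On that basis compound 4 is expected to give 2% in this assay, with a likely range from -6% to 12%.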

Compound 4, a percentage reported as inhibition, in the whole organism at one dose (the size of the read-out at that dose, not a potency): 2.6%
Compound 4: middle estimate off by 0.6 percentage points, on the low side; the range from low to high includes it.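

In this assay the replacement of 2-chlorophenyl by 3-chlorophenyl on a saturated chain carbon bound to a sulfur gave a number 1.5 percentage points lower from compound 3 to compound 4 (within the scatter), so on the second core, as on the first, the change stayed inside the usual spread of the measurement. Set side by side, the two steps cannot be told apart, and the change carries from one core to the other without any detectable difference: the same change on two cores in this assay, a number 7.7 percentage points lower (within the scatter) from compound 1 to compound 2 and a number 1.5 percentage points lower (within the scatter) from compound 3 to compound 4, 6.2 percentage points apart, within the scatter of two such steps

Going by these compounds alone, this does not show that the change has no effect, or that it has a fixed size on both cores, since neither step stands clear of the scatter, each core supplies only one pair, and compound 3 at 4.1% and compound 4 at 2.6% both sit so near the bottom of the scale that a drop of any size would have little room to appear.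

The compounds shown leave open what an unsubstituted benzyl group, a bromobenzyl group or a longer chain on the sulfur would give in place of the chlorobenzyl groups. They also leave open whether the same change would stand out from the scatter on a core that reads well above compound 1 at 21%, where a step would have more room to show.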